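Ester to acid on a shared core

The compounds below may be only part of what the source reports. "The series", "measured", "known", "first", "only" and "open" are said of these compounds alone.

Measured in a functional assay on MCF7 cells (Homo sapiens) for inhibition, read by sulforhodamine B assay, with a stated time of 72 h; a lower number here means a stronger inhibitor of growth, a higher number a weaker inhibitor of growth:
- compound 1 `CNC(=O)/C=C/c1ccncc1-c1ccc2ccccc2c1`: 9340 nM
- compound 2 `CCOC(=O)/C=C/c1ccncc1-c1ccc2c(cnn2C)c1`: 7320 nM
- compound 3 `NNC(=O)CCc1ccncc1-c1ccc2ccccc2c1`: > 10000 nM (a limit, not a number)

Compound 2 gives 7320 nM, which lies within the scatter of compound 1 at 9340 nM. The two therefore cannot be ranked.

Compound 4 `Cn1ncc2cc(-c3cnccc3/C=C/C(=O)O)ccc21` is the next step from compound 2: hydrogen in place of ethyl on an oxygen next to a carbonyl group. In words, hydrogen takes the place of ethyl on an oxygen next to a carbonyl group, so ethoxycarbonyl becomes carboxy.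

Among the measured compounds shown here, no measured step covers this change. The only one available, an at least 1.0-fold higher number from compound 1 to compound 3 (0.02 log units; that floor lies within the scatter), swaps different groups and stays within the scatter. It also rests on a limit, described by the limit of > 10000 nM in this assay, at which 1 of the 3 values shown sits. With so little to go on, no shift beyond the scatter is expected in this assay, and compound 4 may also return only a limit. The expected change is a 1.2-fold higher number from compound 2 to compound 4 (0.09 log units; within the scatter). For compound 4 the estimate is 9000 nM, with an expected range from 4000 nM to 20000 nM.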

Compound 4, concentration for 50% growth inhibition: > 10000 nM
Compound 4: no number, only a limit (the forecaster's own chance of this, stated with the estimate: 45%); middle value at least 1.1-fold (0.04 log units) from the limit.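

In this assay compound 4 gives > 10000 nM, which is a limit of the assay and not a number. On these data alone, the step therefore has only a floor, an at least 1.3-fold higher number from compound 2 to compound 4 (0.13 log units; that floor lies within the scatter), so this change from ethoxycarbonyl to carboxy shows no shift beyond the scatter, and its true size remains unknown. Compound 2 keeps a measured value while its carboxy partner does not, and such readings are no longer a single case: the limit of > 10000 nM in this assay, at which 2 of the 4 values shown sit.

The compounds shown leave open what number compound 4 would have if one could be read. They also leave open whether a methyl ester or a propyl ester in place of the ethyl ester, on the same shared core, would give a number in this assay.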